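Carbonate Chain Swap and Expected Cell Inhibition

The compounds below may be only part of what the source reports. "The series", "measured", "known", "first", "only" and "open" are said of these compounds alone.

Measured in an ADME assay on MRC5 cells (Homo sapiens) for inhibition, read by MTT assay, with a stated time of 72 h; on this read-out higher numbers stand for weaker inhibition and lower numbers for stronger inhibition:
- compound 1 `O=C(OCCCCO)OCCc1ccc(O)c(O)c1`: "not determined" (no result reported)
- compound 2 `O=C(OCCCCCCCCO)OCCc1ccc(O)c(O)c1`: > 50000 nM
- compound 3 `CCCCCCOC(=O)OCCc1ccc(O)c(O)c1`: 11200 nM

In this assay, within the data shown here, compound 3 gives 11200 nM, the only actual number among the three. Compound 2 reaches only a limit of the assay, > 50000 nM. Compound 1 has no result and offers no guidance.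

Compound 4 `O=C(OCCc1ccc(O)c(O)c1)OCCc1ccc(O)c(O)c1` has not yet been measured. Its change from compound 3 is 3,4-dihydroxyphenyl in place of butyl on a saturated chain carbon, two bonds along the chain from an oxygen next to a carbonyl group. The plain butyl end therefore gives way to a 3,4-dihydroxyphenyl.

Among the measured compounds shown here, one measured step bears on this, though only loosely, since it involves a different substitution: an at least 4.4-fold lower number from compound 2 to compound 3 (0.64 log units; beyond the scatter). In that step, compound 3 lacks the 2-hydroxyethyl that compound 2 carries, and the chain without it has the lower number. By analogy, replacing the butyl of compound 3 with a group bearing hydrogen-bond donors is expected to raise the number moderately, in the direction of weaker inhibition. The estimated change is a 2.5-fold higher number from compound 3 to compound 4 (0.40 log units; beyond the scatter). The reading could also end at the limit of > 50000 nM in this assay, at which 1 of the 3 values shown sits, giving no number at all. For compound 4 the expected value is 28000 nM, with an estimated range from 10000 nM to 70000 nM.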

Compound 4, half-maximal inhibitory concentration: > 50000 nM
Compound 4 was reported as a limit (the forecaster's own chance of this, stated with the estimate: 45%); middle value at least 1.7-fold (0.25 log units) away from the limit.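

In this assay, setting 3,4-dihydroxyphenyl in place of butyl, on a saturated chain carbon two bonds along the chain from an oxygen next to a carbonyl group, gives an at least 4.4-fold higher number from compound 3 to compound 4 (0.64 log units; beyond the scatter). This step is read against a limit. Only its lower bound is known. Among these compounds, the earlier compounds showed a change at a different place on the chain, so this is the first evidence that the end of the chain at this position also affects the read-out, and that the plain butyl end of compound 3 is not interchangeable with an aromatic one here. Compound 3 now has higher-number neighbours through both of its single-place changes, while the step between compound 2 and compound 4 cannot be read, as each of them gives only a limit: the limit of > 50000 nM in this assay, at which 2 of the 4 values shown sit.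

The compounds shown leave open whether the shift follows the aromatic ring itself or its hydroxyl groups, which a plain phenyl in the same place would separate. They also leave open how an octyl chain or a terminal amine would read at this position, and how far above the limit compound 4 truly lies.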